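From hydroxymethyl to isopropyl: what to expect for compound 4

The compounds below may be only part of what the source reports. "The series", "measured", "known", "first", "only" and "open" are said of these compounds alone.

Compound 1, `COc1cc(Nc2nc(C)cc(N(C)C)n2)ccc1F`: in an ADME assay on Vero cells (Chlorocebus sabaeus) for cytotoxicity (on this read-out lower numbers stand for an effect already at smaller amounts and higher numbers for an effect only at larger amounts of compound), compound 1 gives 31600 nM.
Compound 2, `COc1cc(Nc2nccc(N(C)C)n2)ccc1F`: in this assay compound 2 gives > 50100 nM, a limit of the assay.
Compound 3, `COc1cc(Nc2nc(CO)cc(N(C)C)n2)ccc1F`: in this assay compound 3 gives > 50100 nM, a limit of the assay.

Compound 3 therefore stands at the ceiling of this assay rather than at a number, (the limit of > 50100 nM in this assay, at which 2 of the 3 values shown sit). Compound 4, `COc1cc(Nc2nc(C(C)C)cc(N(C)C)n2)ccc1F`, differs from compound 3 by isopropyl in place of hydroxymethyl on an aromatic carbon. The closest measured comparison is an at least 1.5-fold higher number from compound 1 to compound 3 (0.20 log units; that floor lies within the scatter), the addition of the same hydroxy that compound 4 does without. The other steps, an at least 1.5-fold higher number from compound 1 to compound 2 (0.20 log units; that floor lies within the scatter) and a step that the two limits leave unreadable from compound 2 to compound 3, offer less to go on, the latter running between two limits. Compound 4 carries no hydroxy, so on these numbers it is expected to sit nearer compound 1 than at the limit. Compound 4 is accordingly estimated at 30000 nM, with a range from 10000 nM to 60000 nM. The estimated step of an at least 1.6-fold lower number from compound 3 to compound 4 (0.22 log units; that floor lies within the scatter) is read against a limit and therefore cannot be sized firmly.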

Compound 4, half-maximal effective concentration: > 50100 nM
Compound 4: a limit, no number (the forecaster's own chance of this, stated with the estimate: 35%); at least 1.6-fold (0.22 log units) between middle value and limit.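

Isopropyl, with 0 hydrogen-bond donors, ends at the same limit of this assay as hydroxymethyl, so at this place, next to the ring nitrogen, a hydroxy group is not required for a compound to reach that limit. Against methyl, isopropyl gives an at least 1.5-fold higher number from compound 1 to compound 4 (0.20 log units; that floor lies within the scatter), while the steps from compound 2 and compound 3 to compound 4 run between two limits and cannot be read. Compound 1, with methyl, thus remains the only compound with a number, and the other three cannot be ordered: the limit of > 50100 nM in this assay, at which 3 of the 4 values shown sit.

As far as these compounds go, whether hydrogen, hydroxymethyl and isopropyl differ at all beyond the limit stays open, as does whether methyl truly stands apart from them. From the compounds shown here alone, how an amine, a carboxylic acid or a longer chain at this place would read in this assay also stays open.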